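Acyl ester variation on the shared core: working notes

The compounds below may be only part of what the source reports. "The series", "measured", "known", "first", "only" and "open" are said of these compounds alone.

Compound 1, `C=C1C(=O)[C@@]23C(=O)OC[C@]4([C@@H](OC(C)=O)CCC(C)(C)[C@H]4C=O)[C@@H]2CC[C@H]1[C@H]3OC(=O)c1ccccc1`, gives 2180 nM in a functional assay on MGC-803 cells (Homo sapiens) for inhibition, read by MTT assay; on this read-out higher numbers stand for weaker inhibition and lower numbers for stronger inhibition.
Compound 2, `C=C1C(=O)[C@@]23C(=O)OC[C@]4([C@@H](OC(C)=O)CCC(C)(C)[C@H]4C=O)[C@@H]2CC[C@H]1[C@H]3OC(C)=O`, gives 3470 nM in this assay.
Compound 3, `C=C1C(=O)[C@@]23C(=O)OC[C@]4([C@@H](OC(C)=O)CCC(C)(C)[C@H]4C=O)[C@@H]2CC[C@H]1[C@H]3OC(=O)c1ccc(C)cc1`, gives 1900 nM in this assay.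

Compound 1 holds the second highest of the three numbers; its nearest neighbour is compound 3, its furthest compound 2, and both gaps stay within the scatter. The three compounds share one core and differ only in the acyl group of one ester.

Compound 4, `C=C1C(=O)[C@@]23C(=O)OC[C@]4([C@@H](OC(C)=O)CCC(C)(C)[C@H]4C=O)[C@@H]2CC[C@H]1[C@H]3OC(=O)CCCC`, is not yet measured. It differs from compound 1 in one place: butyl in place of phenyl on a carbonyl carbon.

The step that bears on this is a 1.6-fold higher number from compound 1 to compound 2 (0.20 log units; within the scatter), which replaces the same phenyl with a smaller group and stays within the scatter. The step of a 1.8-fold lower number from compound 2 to compound 3 (0.26 log units; within the scatter) is also within the scatter, so across the three measured compounds the acyl group has not moved the number beyond what repeated measurements show. On that basis the butyl in compound 4 is expected to give no step beyond the scatter, a 1.1-fold higher number from compound 1 to compound 4 (0.06 log units; within the scatter), with the estimate set close to compound 1 because of 2180 nM.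

For compound 4 the expected value in this assay is 2500 nM, with a range from 1200 nM to 5500 nM.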

Compound 4, half-maximal inhibitory concentration: 2490 nM
The estimate for compound 4 lay 1.0-fold (0.00 log units) above the measured number; the range from low to high includes it.
By their numbers in this assay, from the lowest: compounds 3, 1, 4 and 2 (each within the scatter of the next).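

At this ester, compound 4 brings in an acyl group with no ring, whereas phenyl and 4-methylphenyl each carry one six-membered aromatic ring. In this assay the exchange of phenyl for butyl is a 1.1-fold higher number from compound 1 to compound 4 (0.06 log units; within the scatter) and the exchange of 4-methylphenyl for butyl is a 1.3-fold higher number from compound 3 to compound 4 (0.12 log units; within the scatter) so, in these compounds, an aromatic ring on the carbonyl carbon is not needed to keep the number within the scatter. Against the acetate ester, the step is a 1.4-fold lower number from compound 2 to compound 4 (0.14 log units; within the scatter) and shows that adding propyl on the saturated chain carbon bound to the carbonyl carbon also stays within the scatter, leaving all four acyl groups without a separation on this read-out. No measurement available here speaks to the reason for this lack of separation.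

As far as these compounds go, it remains open whether an acyl group carrying an amine or a carboxylic acid, or a chain longer than butyl, would give a step beyond the scatter. The compounds shown also leave open whether a change elsewhere on the shared core would move the number further than any change at this ester.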